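The source may report more compounds than this note shows. Statements on the series, on what has been measured and on what is new or still open speak of the compounds shown alone.

Measured compounds:
compound 1, `N[C@H]1CC[C@H](Nc2c(C(=O)NCc3ccc(F)cc3)nc(N3CCCCC3)c3cccnc23)CC1`: 8500 nM
compound 2, `CS(=O)(=O)Oc1c(C(=O)NCc2ccc(F)cc2)nc(Br)c2cccnc12`: > 20000 nM
compound 3, `C[C@H](CO)Nc1nc(C(=O)NCc2ccc(F)cc2)c(O)c2ncccc12`: "not determined" (no result reported)

In a functional assay on HCT-116 cells (Homo sapiens) for cytotoxicity, read by MTT assay, with a stated time of 72 h (a lower number here means a stronger inhibitor, a higher number a weaker inhibitor), compound 1 gives 8500 nM. Compound 2 is recorded only as a limit of the assay, > 20000 nM, not as a number. Compound 3 has no result in this assay. Going by the values given here, compound 2 therefore stands at the edge of what the assay reports: it sits at the limit of > 20000 nM in this assay, at which 1 of the 3 values shown sits, and the only other entry of the set, compound 3, carries no number either, so no measured step leads to or from compound 2.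

Compound 4, `CNCCCNc1c(C(=O)NCc2ccc(F)cc2)nc(Br)c2cccnc12`, differs from compound 2 in one place: (3-(methylamino)propyl)amino in place of (methylsulfonyl)oxy on an aromatic carbon. The bromo group and the amide bearing the fluorobenzyl part are kept.

Among the compounds with values here, no step between two measured compounds is available here, so the expectation for compound 4 rests on compound 1 alone, whose 8500 nM shows that a compound of this shared core can give a number within the reported range. The step from compound 2 to compound 4 is expected to be an at least 2.5-fold lower number from compound 2 to compound 4 (0.39 log units; beyond the scatter), toward a stronger inhibitor, though the limit on compound 2 leaves its true size open. Compound 4 is estimated at 8000 nM in this assay, with a range from 2500 nM to 20000 nM.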

Compound 4, half-maximal inhibitory concentration: > 10000 nM
Compound 4 ended at the assay's limit; the forecaster's own chance of this, stated with the estimate: 30%; middle value at least 1.2-fold (0.09 log units) from the limit.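

In this assay compound 4 is recorded only as a limit, > 10000 nM. Compound 2 is likewise recorded only as a limit, > 20000 nM. The two limits leave the step between compound 2 and compound 4 unreadable. The compounds shown leave open whether (3-(methylamino)propyl)amino in place of (methylsulfonyl)oxy changes the value at all.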